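Swapping the chain on the carbonyl of compound 3

The source may report more compounds than this note shows. Statements on the series, on what has been measured and on what is new or still open speak of the compounds shown alone.

Of the compounds shown here, three sharing one core have been measured in an assay on HEK293 cells for displacement of a labelled ligand from Melanocortin receptor 4 (Homo sapiens); a higher number here means a weaker inhibitor, a lower number a stronger inhibitor. Compound 1 `COc1ccc(OCC(=O)N2CCN(c3ccc(C(F)(F)F)cc3[C@@H](N)CC(C)C)CC2)cc1` gives 3800 nM; compound 2 `CC(C)C[C@H](N)c1cc(C(F)(F)F)ccc1N1CCN(C(=O)COc2ccc(O)cc2)CC1` gives 4600 nM; compound 3 `CC(C)C[C@H](N)c1cc(C(F)(F)F)ccc1N1CCN(C(=O)CCC2CCCCC2)CC1` gives 5700 nM. Compound 3 sits with the others: the steps of a 1.5-fold higher number from compound 1 to compound 3 (0.18 log units; within the scatter) and a 1.2-fold higher number from compound 2 to compound 3 (0.09 log units; within the scatter) do not set it apart, and a 1.2-fold higher number from compound 1 to compound 2 (0.08 log units; within the scatter) is likewise small. Compound 4 `COc1ccc(CC(C)C(=O)N2CCN(c3ccc(C(F)(F)F)cc3[C@@H](N)CC(C)C)CC2)cc1` differs from compound 3 by 1-(4-methoxybenzyl)ethyl in place of 2-cyclohexylethyl on a carbonyl carbon. The two steps onto compound 3 changed this same chain, once from 4-methoxyphenoxy and once from 4-hydroxyphenoxy, and neither moved the number beyond the scatter. The return of a methoxy-bearing aromatic ring in compound 4 is therefore expected to give a step of a 1.4-fold lower number from compound 3 to compound 4 (0.13 log units; within the scatter), with compound 4 estimated at 4200 nM, within 1500 nM to 12000 nM.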

Compound 4, inhibition constant: 120 nM
Compound 4: the middle estimate sits 35-fold (1.54 log units) above what was measured; the measured number lies below the stated range.
By their numbers in this assay, from the lowest: compound 4; then compounds 1, 2 and 3 (each within the scatter of the next).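

In this assay the group on this carbonyl carbon can matter greatly: 1-(4-methoxybenzyl)ethyl brings a 48-fold lower number from compound 3 to compound 4 (1.68 log units; beyond the scatter) in place of 2-cyclohexylethyl, a 38-fold lower number from compound 2 to compound 4 (1.58 log units; beyond the scatter) in place of (4-hydroxyphenoxy)methyl, and a 32-fold lower number from compound 1 to compound 4 (1.50 log units; beyond the scatter) in place of (4-methoxyphenoxy)methyl. Both groups in the last step carry a methoxy-bearing aromatic ring, so that ring alone does not give the gain. Nothing available explains why this group does. Still open, going by these compounds, is whether an unbranched 2-(4-methoxyphenyl)ethyl chain would do the same, and what a hydroxy group in place of the methoxy would give on this chain.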